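Lengthening the hydroxycarbamoyl chain of compound 1

The source may report more compounds than this note shows. Statements on the series, on what has been measured and on what is new or still open speak of the compounds shown alone.

Compound 1 `COc1cc2c(Oc3ccc(NC(=O)c4nn(-c5ccccc5C)cc(C)c4=O)cc3)ccnc2cc1OCC(=O)NO` gives 5980 nM
Compound 2 `COc1cc2c(Oc3ccc(NC(=O)c4nn(-c5ccccc5C)cc(C)c4=O)cc3F)ccnc2cc1OCCCC(=O)NO` gives 2090 nM

Both numbers come from a functional assay on A549 cells (Homo sapiens) for inhibition, read by MTT assay, with a stated time of 72 h (on this read-out higher numbers stand for weaker inhibition and lower numbers for stronger inhibition), and they are the only two available. Compound 1 holds the higher of the two, which makes it the weaker inhibitor of the pair, and the gap to compound 2 lies beyond the usual scatter.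

Compound 3 `COc1cc2c(Oc3ccc(NC(=O)c4nn(-c5ccccc5C)cc(C)c4=O)cc3)ccnc2cc1OCCCCCCC(=O)NO` keeps the core of compound 1 and alters a single place (5-(hydroxycarbamoyl)pentyl in place of hydroxycarbamoyl on a saturated chain carbon bound to an oxygen on an aromatic ring). A 5-(hydroxycarbamoyl)pentyl group stands in place of hydroxycarbamoyl, on a saturated chain carbon bound to an oxygen on an aromatic ring.

For the measured compounds named here, no measured pair isolates this change. Set against compound 1, compound 2 carries a longer chain but also differs in a second place, and compound 2 (2090 nM) is only a loose guide to what length alone does. On that guide, a moderate move toward stronger inhibition, beyond the scatter, is expected, and the estimated step is a 4.6-fold lower number from compound 1 to compound 3 (0.66 log units; beyond the scatter) in this assay with wide uncertainty. Compound 3 is expected at 1300 nM (estimated range 350 nM to 4500 nM).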

Compound 3, half-maximal inhibitory concentration: 3130 nM
For compound 3 the middle estimate is 2.4-fold (0.38 log units) below the measured one; the measured number falls inside the stated range.
By their numbers in this assay, from the lowest: compounds 2, 3 and 1 (each within the scatter of the next, the first and the last beyond it).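

In this assay, putting 5-(hydroxycarbamoyl)pentyl in place of hydroxycarbamoyl on a saturated chain carbon bound to an oxygen on an aromatic ring gives a 1.9-fold lower number from compound 1 to compound 3 (0.28 log units; within the scatter) for a change made in one place only. For the compounds shown here, this is the first reading of chain length alone with the core of compound 1 held constant, and the step is too small to separate from the ordinary variation between repeated measurements. At this position, the longer chain therefore shows no clear effect on the read-out, and the data offered here give no explanation for that result.

Compound 2 differs from compound 1 in two places, so its steps to compound 1 and compound 3 cannot be read as the effect of any single change. Still open, on these data alone, is whether a longer chain than 5-(hydroxycarbamoyl)pentyl would produce a step beyond the scatter, and whether a carboxylic acid or an amine at the chain end would give a number different from that of hydroxycarbamoyl.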